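A sulfur-bearing arm on the sulfonamide nitrogen

The source may hold more compounds than are shown below. What is called first, only, known or untested is meant among the compounds shown, and "the series" means these compounds.

Compound 1 `Cc1cc(C)n(-c2ccc(S(=O)(=O)NC(=O)NNC(=N)N)cc2)n1`: 3%
Compound 2 `Cc1cc(C)n(-c2ccc(S(=O)(=O)NC(=O)NC3CCCCC3)cc2)n1`: 10%
Compound 3 `Cc1cc(C)n(-c2ccc(S(=O)(=O)NC(=O)NCc3ccccc3)cc2)n1`: < 1%

In a functional assay on the whole organism (blood, strain albino) with Mus musculus as the target, with stated times of 6 days and 4 h, at a dose of 0.4 mmol/kg by the oral route (a lower number here means less inhibition, a higher number more inhibition at the dose given (going by the name of the read-out)), compound 1 gives 3%; of the two plain numbers it is the lower, yet the step of a number 7 percentage points higher from compound 1 to compound 2 (within the scatter) stays within the scatter. Compound 3 reports only a limit of the assay, < 1%. This is the limit of < 1% in this assay, at which 1 of the 3 values shown sits. Compound 4 `C=CCNC(=S)NS(=O)(=O)c1ccc(-n2nc(C)cc2C)cc1` alters compound 1 at another spot: a group of 6 heavy atoms (4 carbon, 1 nitrogen, 1 sulfur; no ring) in place of a group of 7 heavy atoms (2 carbon, 4 nitrogen, 1 oxygen; no ring), on a sulfonamide nitrogen. The measured steps sit on the amide-type nitrogen and were a number 7 percentage points higher from compound 1 to compound 2 (within the scatter) and a number at least 2 percentage points lower from compound 1 to compound 3 (that floor lies within the scatter), neither beyond the scatter, so nothing beyond the scatter is expected from this change either. Compound 4 is therefore estimated at 5%, ranging from 0% to 15%. That estimate means a number 2 percentage points higher from compound 1 to compound 4 (within the scatter) is expected.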

Compound 4, a percentage reported as inhibition, in the whole organism at one dose (the size of the read-out at that dose, not a potency): -1%
Compound 4: the middle estimate sits 6 percentage points above what was measured, and the stated range ends above it.
By their numbers in this assay, from the lowest: compounds 4, 1 and 2 (each within the scatter of the next, the first and the last beyond it).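

Here the change reaches the sulfonamide nitrogen itself, not only the amide-type nitrogen, and in this assay the sulfur-bearing group gives a number 4 percentage points lower from compound 1 to compound 4 (within the scatter). Even with 4 hydrogen-bond donors giving way to 1, the read-out moves no further than the scatter. Compound 3 reports only a limit, and the other low values lie near it: the limit of < 1% in this assay, at which 1 of the 4 values shown sits.

From the compounds shown here alone, whether a carboxylic acid or a simple amine on this nitrogen would raise the inhibition beyond the scatter stays open.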